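From oxanyl ethyl to methylcarbamoyl cyclohexyl

The source may hold more compounds than are shown below. What is called first, only, known or untested is meant among the compounds shown, and "the series" means these compounds.

Measured so far in an ADME assay on S9 fraction from liver (Homo sapiens) for metabolic stability, with a stated time of 1 h; a higher number here means that more of the compound is left, a lower number that less of the compound is left:
- compound 1 `N#Cc1cnc(NCc2cnccc2C(F)(F)F)cc1NC[C@H]1C[C@@H](O)C1` gives 84% remaining
- compound 2 `N#Cc1cnc(NCc2cnccc2C(F)(F)F)cc1N[C@H]1CC[C@H](O)CC1` gives 30% remaining
- compound 3 `N#Cc1cnc(NCc2cnccc2C(F)(F)F)cc1NCCC1CCOCC1` gives 23% remaining

Compound 3 stands level with compound 2 within the scatter, and both lie far under compound 1. Compound 4 `CNC(=O)[C@H]1CC[C@@H](Nc2cc(NCc3cnccc3C(F)(F)F)ncc2C#N)CC1` carries 4-(methylcarbamoyl)cyclohexyl in place of 2-(oxan-4-yl)ethyl on a nitrogen on an aromatic ring. The step between the two nearest compounds (a number 7 percentage points lower from compound 2 to compound 3 (within the scatter)) stays within the scatter. The large steps (a number 54 percentage points lower from compound 1 to compound 2 (beyond the scatter)) and (a number 61 percentage points lower from compound 1 to compound 3 (beyond the scatter)) both start from compound 1, whose (3-hydroxycyclobutyl)methyl group compound 4 lacks. Compound 4 shares a cyclohexyl ring with compound 2 (30%), so only a modest rise is expected (a number 17 percentage points higher from compound 3 to compound 4 (beyond the scatter)). Compound 4 is estimated at 40% (range 18% to 70%).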

Compound 4, percent of the compound remaining: 71%
The estimate for compound 4 lay 31 percentage points below the measured number; measured number outside the range, above it.
By their numbers in this assay, from the lowest: compounds 3 and 2 (each within the scatter of the next); then compound 4; then compound 1.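

In this assay the swap of 2-(oxan-4-yl)ethyl for 4-(methylcarbamoyl)cyclohexyl on this nitrogen gives a large rise (a number 48 percentage points higher from compound 3 to compound 4 (beyond the scatter)). With the cyclohexyl ring kept, changing 4-hydroxy to methylcarbamoyl also gives a large rise (a number 41 percentage points higher from compound 2 to compound 4 (beyond the scatter)), so a cyclohexyl ring here does not by itself fix a low number, though compound 1 stays modestly ahead (a number 13 percentage points lower from compound 1 to compound 4 (beyond the scatter)). Nothing measured here explains these steps.

Going by these compounds, whether a dimethylcarbamoyl group or a carboxylic acid on the same cyclohexyl ring would hold this number remains open.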